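Tert-butyl to 2-methoxyphenyl on the amide-type nitrogen

A few compounds are considered here, and "the series" means these few. Any claim that something is new, unique, unknown or untested is made for them only; others in the source may bear on it.

Of the compounds shown here, two on the shared core have been measured in an ADME assay on THP-1 cells (Homo sapiens) for cytotoxicity; a lower number here means that less compound is tolerated, a higher number that more compound is tolerated: compound 1 (`COc1ccc(CNC(=O)c2c(NC(=O)C(F)(F)F)sc3c2CCCCC3)cc1`) and compound 2 (`CC(C)(C)NC(=O)c1c(NC(=O)C(F)(F)F)sc2c1CCCCC2`). Compound 1 gives > 50000 nM, a limit and not a number. Compound 2 gives > 50000 nM, also a limit and not a number. Compound 2 therefore stands at the limit of > 50000 nM in this assay, at which 2 of the 2 values shown sit, with no number to fix its place.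

For the measured compounds named here, the only measured step, a step that the two limits leave unreadable from compound 1 to compound 2, gives no size to carry forward. The next change leads to compound 3 (`COc1ccccc1NC(=O)c1c(NC(=O)C(F)(F)F)sc2c1CCCCC2`), with 2-methoxyphenyl in place of tert-butyl on an amide-type nitrogen.

Going by the values given here, no measured compound carries 2-methoxyphenyl, so the expectation rests only on compound 1 and compound 2 both sitting at the limit of > 50000 nM in this assay, at which 2 of the 2 values shown sit. No change beyond the scatter is expected, and any change that does appear would more likely be towards less compound tolerated in this assay. The expected size is an at least 1.1-fold lower number from compound 2 to compound 3 (0.04 log units; that floor lies within the scatter). Another report of only a limit is the likeliest outcome. For compound 3 the estimated value is 45000 nM, with an expected range of 20000 nM to 50000 nM.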

Compound 3, half-maximal cytotoxic concentration: > 50000 nM
Compound 3: only a limit was reported; the forecaster's own chance of this, stated with the estimate: 65%; at least 1.1-fold (0.04 log units) between middle value and limit.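

In this assay compound 3 gives > 50000 nM, a limit and not a number. The steps among compound 1, compound 2 and compound 3 cannot be read, as all three are reported only as limits. The compounds shown leave open whether the group on the amide-type nitrogen shifts the half-maximal cytotoxic concentration at all, with every value at one limit: the limit of > 50000 nM in this assay, at which 3 of the 3 values shown sit.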